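A few compounds are considered here, and "the series" means these few. Any claim that something is new, unique, unknown or untested is made for them only; others in the source may bear on it.

Of the compounds shown here, three have been measured in a functional assay on HepG2 cells (Homo sapiens) for cytotoxicity, with a stated time of 72 h; on this read-out lower numbers stand for stronger inhibition and higher numbers for weaker inhibition. Compound 1 `C#CCOc1ccc(/C=C/C(=O)c2cccc(Br)c2)cc1OC` gives 10100 nM. Compound 2 `C=CCc1cc(C(C)=O)ccc1OCC=C(C)C` gives 14700 nM, and compound 3 `C#CCOc1ccc(/C=C/C(=O)c2ccc(-n3ccnc3)cc2)cc1OC` gives 5390 nM. Among these three numbers the reading of compound 1 stands second highest, yet its gaps to compound 2 and to compound 3 both lie within the usual scatter of repeated measurements, so the three readings cannot be told apart. Compound 4 `C#CCOc1ccc(/C=C/C(=O)c2ccccc2C)cc1OC` has not yet been measured. It differs from compound 1 in one place: 2-methylphenyl in place of 3-bromophenyl on a carbonyl carbon. Among the measured compounds shown here, no measured pair shows what such an exchange of one aromatic group for another does here, so in this assay the expected step is a 1.1-fold lower number from compound 1 to compound 4 (0.03 log units; within the scatter), no larger than the scatter. Compound 4 is therefore estimated at 9500 nM, with a range from 4000 nM to 22000 nM.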

Compound 4, half-maximal inhibitory concentration: 2640 nM
Estimate against measurement, compound 4: 3.6-fold (0.56 log units) above; measured number outside the range, below it.
By their numbers in this assay, from the lowest: compound 4; then compounds 3, 1 and 2 (each within the scatter of the next, the first and the last beyond it).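

The earlier compounds shown here offered no pair that differed in one place. Here, this assay shows a 3.8-fold lower number from compound 1 to compound 4 (0.58 log units; beyond the scatter) with 2-methylphenyl in place of 3-bromophenyl on a carbonyl carbon, so the aromatic group at this place can shift the reading beyond the scatter, though the step is modest. Both groups count the same number of heavy atoms, and nothing at hand accounts for the step.

Plain phenyl at this place could read like compound 1, like compound 4 or somewhere else, so it remains open whether the loss of bromine or the gain of methyl matters more. As far as these compounds go, how an aminophenyl group would read there is also open.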